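The compounds below may be only part of what the source reports. "The series", "measured", "known", "first", "only" and "open" are said of these compounds alone.

Working notes on a small set of pyridine-carboxamide tetrazoles carrying a para-substituted phenyl ring.

Compound 1 `CCOc1cc(C(=O)Nc2nn[nH]n2)nc(-c2ccc(N)cc2)c1` is the reference member. In a functional assay on the whole organism for inhibition, with Rattus norvegicus as the target, at a dose of 0.3 mg/kg by the oral route (a lower number here means a weaker effect, a higher number a stronger effect of the compound at the dose given), compound 1 gives 19%. Compound 2 `CCCOc1cc(C(=O)Nc2nn[nH]n2)nc(-c2ccc(N)cc2)c1` differs from compound 1 only by methyl in place of hydrogen on a saturated chain carbon, two bonds along the chain from an oxygen on an aromatic ring. In this assay compound 2 gives 7%, which is a number 12 percentage points lower from compound 1 to compound 2 (beyond the scatter).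

Compound 3 `CCCc1ccc(-c2cc(C)cc(C(=O)Nc3nn[nH]n3)n2)cc1` belongs to a second core; the difference between the core of compound 3 and the core of compound 1 is not broken down here. In this assay compound 3 gives 19%, level with compound 1 at the digits printed and, with it, the higher of the measured numbers, while compound 2 sits below both.

Compound 4 `CCCCc1ccc(-c2cc(C)cc(C(=O)Nc3nn[nH]n3)n2)cc1` is not yet measured. It differs from compound 3 by methyl in place of hydrogen on a saturated chain carbon, three bonds along the chain from an aromatic carbon. This is the same kind of change as that from compound 1 to compound 2, though not the same: there the entering methyl stands two bonds along the chain from an oxygen on an aromatic ring, whereas here it stands three bonds along the chain from an aromatic carbon, with no oxygen in the chain.

Among the measured compounds shown here, the only precedent for chain extension of this kind is a number 12 percentage points lower from compound 1 to compound 2 (beyond the scatter), a modest lowering. The step expected is a number 9 percentage points lower from compound 3 to compound 4 (within the scatter), resting on a number 12 percentage points lower from compound 1 to compound 2 (beyond the scatter) and tempered by the different surroundings of the place, which keep the expectation loose. On that basis compound 4 is expected to give about 10% in this assay. The range expected for compound 4 runs from 0% to 24%.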

Compound 4, a percentage reported as inhibition, in the whole organism at one dose (the size of the read-out at that dose, not a potency): 17%
Beside the measured number, compound 4's estimate is 7 percentage points below it; the measured number falls inside the stated range.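

In this assay, methyl in place of hydrogen on a saturated chain carbon gives a number 2 percentage points lower from compound 3 to compound 4 (within the scatter), and set beside the earlier step on the other core, the two readings do not separate: the same change on two cores in this assay, a number 12 percentage points lower (beyond the scatter) from compound 1 to compound 2 and a number 2 percentage points lower (within the scatter) from compound 3 to compound 4, 10 percentage points apart, within the scatter of two such steps. On these two pairs, then, the change can be read across from the core of compound 1 to the core of compound 3 without a gap that stands out, and in neither pair does the longer chain give a number beyond the scatter in the upward direction. Among the compounds shown here, this does not show that the step is the same on both cores, since only two pairs are at hand, just one of the two steps lies beyond the scatter, the entering methyl stands in a different place in each pair, and each number is a read-out at one dose rather than a potency.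

The compounds shown leave open how the read-out runs on either core with a chain longer than butyl, or with a branched chain in its place. They also leave open what a chain carrying a carboxylic acid or a nitrile would give in this assay.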